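The source may hold more compounds than are shown below. What is called first, only, known or untested is meant among the compounds shown, and "the series" means these compounds.

In an assay on isolated protein for inhibition of protein tyrosine phosphatase type IVA 3 (Homo sapiens), tested at 5 ug/mL (a higher number here means more inhibition at the concentration tested (going by the name of the read-out), a lower number less inhibition), the measured compounds gave:
- compound 1 `O=C1NC(=S)S/C1=C\C=C\c1ccccc1`: 37.4%
- compound 2 `COc1ccccc1COc1ccccc1/C=C/C=C1\SC(=S)NC1=O`: 78.8%
- compound 3 `COc1cccc(COc2ccccc2/C=C/C=C2\SC(=S)NC2=O)c1`: 52.9%

Compound 3 stands second highest of the three numbers: compound 2 lies above it by a number 25.9 percentage points lower from compound 2 to compound 3 (beyond the scatter) reversed, and compound 1, which carries no group on the aromatic ring at all, lies below it beyond the scatter. Compound 4 `O=C1NC(=S)S/C1=C\C=C\c1ccccc1OCc1ccncc1` arises from compound 3 by the change (pyridin-4-yl in place of 3-methoxyphenyl on a saturated chain carbon bound to an oxygen on an aromatic ring). Within the data shown here, the only measured step, a number 25.9 percentage points lower from compound 2 to compound 3 (beyond the scatter), concerns a shift of the methoxy group, not an exchange of the ring itself, so it bears on this change only loosely. Among the measured compounds shown here, with no direct precedent, no step beyond the scatter is expected, the estimated step being a number 2.9 percentage points lower from compound 3 to compound 4 (within the scatter). Compound 4 is therefore expected to give 50%, within 30% to 72%.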

Compound 4, a percentage reported as inhibition, at one concentration (the size of the read-out at that concentration, not a potency): 39.4%
Estimate against measurement, compound 4: 10.6 percentage points above, within the range that was stated.
By their numbers in this assay, from the lowest: compounds 1 and 4 (each within the scatter of the next); then compound 3; then compound 2.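

In this assay, the ring on the saturated chain carbon matters: pyridin-4-yl in place of 3-methoxyphenyl gives a number 13.5 percentage points lower from compound 3 to compound 4 (beyond the scatter), and pyridin-4-yl in place of 2-methoxyphenyl gives a number 39.4 percentage points lower from compound 2 to compound 4 (beyond the scatter). The whole (pyridin-4-yl)methoxy group in place of hydrogen on an aromatic carbon gives a number 2 percentage points higher from compound 1 to compound 4 (within the scatter), so this added group shows no gain over the core of compound 1. No measurement at hand explains these steps.

From the compounds shown here alone, it stays open whether the ring nitrogen or the loss of the methoxy group lies behind the lower numbers. A plain phenyl at this place would separate the two.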